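Swapping an oxolan-3-yl for a methyl on a quinazoline urea series

A few compounds are considered here, and "the series" means these few. Any claim that something is new, unique, unknown or untested is made for them only; others in the source may bear on it.

Measured compounds:
- compound 1, `N#Cc1ccc(/C=N/NC(=O)Nc2cc3c(Nc4ccc(F)c(Cl)c4)ncnc3cc2O[C@H]2CCOC2)cc1`, 28100 nM
- compound 2, `CC(C)(C)c1cc(/C=N/NC(=O)Nc2cc3c(Nc4ccc(F)c(Cl)c4)ncnc3cc2O[C@H]2CCOC2)cc(C(C)(C)C)c1O`, 13100 nM
- compound 3, `COc1cc2ncnc(Nc3ccc(F)c(Cl)c3)c2cc1NC(=O)N/N=C/c1ccc(C#N)cc1`, 36500 nM

All three were tested in a functional assay on PC-3 cells (Homo sapiens) for cytotoxicity, read by MTT assay, with a stated time of 72 h; a higher number here means a weaker inhibitor, a lower number a stronger inhibitor. Compound 1 gives 28100 nM, compound 3 gives 36500 nM, and compound 2 gives 13100 nM, the lowest of the three numbers, with its gaps to compound 1 and to compound 3 both beyond the usual scatter.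

Compound 1 and compound 3 differ in one place only: methyl in place of oxolan-3-yl on an oxygen on an aromatic ring. That change gave a 1.3-fold higher number from compound 1 to compound 3 (0.11 log units; within the scatter), a step that lies within the scatter, so the two compounds are indistinguishable in this assay.

Compound 4, `COc1cc2ncnc(Nc3ccc(F)c(Cl)c3)c2cc1NC(=O)N/N=C/c1cc(C(C)(C)C)c(O)c(C(C)(C)C)c1`, has not yet been measured. It stands to compound 2 exactly as compound 3 stands to compound 1: methyl in place of oxolan-3-yl on an oxygen on an aromatic ring. The place of the change is the same in both pairs, so this is the same change made on a different core. The difference between the core of compound 2 and the core of compound 1 is not broken down here.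

Because the earlier step was a 1.3-fold higher number from compound 1 to compound 3 (0.11 log units; within the scatter), the step from compound 2 to compound 4 is expected to be similar, a 1.2-fold higher number from compound 2 to compound 4 (0.09 log units; within the scatter), which rests on one prior example only. Compound 4 is therefore estimated at 16000 nM in this assay, expected to fall between 7000 nM and 40000 nM.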

Compound 4, half-maximal inhibitory concentration: 28700 nM
Compound 4: middle estimate off by 1.8-fold (0.25 log units), on the low side; the measured number falls inside the stated range.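

In this assay, putting methyl in place of oxolan-3-yl on the aromatic ring's oxygen gave a 2.2-fold higher number from compound 2 to compound 4 (0.34 log units; beyond the scatter), a modest step in the direction of a weaker inhibitor. Set beside the earlier step on the other core, the size of the change cannot be told apart from one core to the other, so in this small set it carries over reasonably well: the same change on two cores in this assay, a 1.3-fold higher number (0.11 log units; within the scatter) from compound 1 to compound 3 and a 2.2-fold higher number (0.34 log units; beyond the scatter) from compound 2 to compound 4, 1.7-fold (0.23 log units) apart, within the scatter of two such steps This does not show that the change has a real effect on every core, since only the step on the core of compound 2 lies beyond the scatter, and two pairs can neither predict the step on a third core nor explain why the change acts as it does.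

The compounds shown leave open how other groups on the same oxygen, such as an ethyl, a longer chain ending in an amine, or the oxolan-3-yl with its stereocentre reversed, would compare with methyl and with the oxolan-3-yl used here. They also leave open whether the same small step would appear on a core carrying a different group on its hydrazone end, such as a carboxylic acid.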